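The source may hold more compounds than are shown below. What is called first, only, known or untested is meant among the compounds shown, and "the series" means these compounds.

Working notes on the series in a functional assay on BGC-823 cells (Homo sapiens) for cytotoxicity, read by MTT assay, with a stated time of 48 h; on this read-out lower numbers stand for stronger inhibition and higher numbers for weaker inhibition. Three members carry numbers: compound 1 (`O=C(CSc1nnc(-c2ccncc2)o1)N/N=C/c1ccc(O)cc1`) gives 7940 nM, compound 2 (`Cc1ccc(/C=N/NC(=O)CSc2nnc(-c3ccncc3)o2)cc1`) gives 21800 nM and compound 3 (`O=C(CSc1nnc(-c2ccncc2)o1)N/N=C/c1cc(Cl)cc(Cl)c1O`) gives 6340 nM. On these numbers, compound 3 cannot be separated from compound 1 but stands clear of compound 2. The two steps that place it are a 1.3-fold lower number from compound 1 to compound 3 (0.10 log units; within the scatter) and a 3.4-fold lower number from compound 2 to compound 3 (0.54 log units; beyond the scatter).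

The next member is compound 4 (`O=C(CSc1nnc(-c2ccncc2)o1)N/N=C/c1cccs1`), with the change thiophen-2-yl in place of 3,5-dichloro-2-hydroxyphenyl on a carbon with a double bond to nitrogen. For the measured compounds named here, no measured step brings in thiophen-2-yl, so the evidence is indirect. All three measured steps fall at this same place and none is large. The two members with a hydroxy group sit together, while compound 2, the only one without it, lies higher, as shown by a 2.7-fold higher number from compound 1 to compound 2 (0.44 log units; beyond the scatter). Compound 4 also has no hydroxy group, and that makes a modest rise in this assay the likeliest outcome, though three compounds are thin support. The estimated step is a 2.2-fold higher number from compound 3 to compound 4 (0.34 log units; beyond the scatter). Compound 4 is expected at 14000 nM, with an estimated range of 6000 nM to 32000 nM.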

Compound 4, half-maximal inhibitory concentration: 26700 nM
Compound 4: the middle estimate sits 1.9-fold (0.28 log units) below what was measured; low and high end bracket the measured number.
By their numbers in this assay, from the lowest: compounds 3 and 1 (each within the scatter of the next); then compounds 2 and 4 (each within the scatter of the next).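

In this assay, for the compounds shown here, thiophen-2-yl is the first group at this carbon with a double bond to nitrogen that is a five-membered aromatic ring with a hetero atom, and it cannot be separated from 4-methylphenyl, with a 1.2-fold higher number from compound 2 to compound 4 (0.09 log units; within the scatter) within the scatter. Against the two members carrying a hydroxy group the change stands clear, with a 4.2-fold higher number from compound 3 to compound 4 (0.62 log units; beyond the scatter) and a 3.4-fold higher number from compound 1 to compound 4 (0.53 log units; beyond the scatter) on this read-out, so the split between compound 1 and compound 3 on the stronger side and compound 2 and compound 4 on the weaker side now spans two ring types, and none of the four compounds goes against it. No supporting data bear on why the members fall into these two groups.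

Going by these compounds alone, the four compounds do not show whether the hydroxy group alone carries the split, as no member pairs it with a five-membered ring and none has an unsubstituted phenyl at this carbon. Also open, from the compounds shown here alone, is how an amine such as 4-dimethylaminophenyl, a carboxylic acid on the phenyl ring, or furan-2-yl would sit relative to these two groups.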